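This account rests on a few compounds, and the source may have more. Where it says the series, first, only, none or still open, it means among the compounds named here.

Working notes on the series.

The set contains three compounds on a shared core. Compound 1 is `COc1ccc(Nc2nc(Oc3cccc(NC(=O)/C=C/C(C)C)c3)c3sccc3n2)cc1`; in an ADME assay on L02 cells (Homo sapiens) for inhibition, read by MTT assay, with a stated time of 72 h (a higher number here means a weaker inhibitor, a lower number a stronger inhibitor), the entry for compound 1 stands as "not determined" (no result reported), so no number is available for it. Going by the values given here, compound 2 is `C/C=C/C(=O)Nc1cccc(Oc2nc(Nc3cccc(OC)c3)nc3ccsc23)c1`; in this assay compound 2 gives 46000 nM, which is the only number recorded in the set. Among the compounds with values here, compound 2 therefore has no measured neighbour against which its figure could be placed, and no measured step exists anywhere.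

Compound 3 is `CC/C=C/C(=O)Nc1cccc(Oc2nc(Nc3cccc(OC)c3)nc3ccsc23)c1`. It differs from compound 2 in one place: methyl in place of hydrogen on a saturated chain carbon bound to a double-bonded chain carbon. The change lies on the chain that carries the amide, away from the core and away from the aryl ether.

Within the data shown here, with no measured step in hand, the expectation rests on the size of the change alone. For a single added carbon on a saturated chain carbon, the expected step from compound 2 to compound 3 in this assay is no change at the digits printed from compound 2 to compound 3 (within the scatter), in no particular direction and not beyond the usual scatter. Compound 3 is accordingly estimated at 46000 nM, with a range from 20000 nM to 100000 nM.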

Compound 3, half-maximal inhibitory concentration: > 50000 nM
Compound 3: only a limit was reported (the forecaster's own chance of this, stated with the estimate: 20%); at least 1.0-fold (0.03 log units) between middle value and limit.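

The place on the saturated chain carbon bound to a double-bonded chain carbon now has its first reading in this assay, and the change from prop-1-en-1-yl to but-1-en-1-yl gives an at least 1.0-fold higher number from compound 2 to compound 3 (0.03 log units; that floor lies within the scatter). The reading for compound 3 is a limit and not a number: the limit of > 50000 nM in this assay, at which 1 of the 3 values shown sits. Methyl in place of hydrogen at this place therefore shows no step beyond the scatter, but the step has a floor only and no upper bound, so this does not show that the two compounds match.

As far as these compounds go, whether a longer chain at this place, or an amine or a carboxylic acid carried on the same chain, would shift the reading in this assay remains open. Also open, from the compounds shown here alone, is how far the true number for compound 3 lies past its limit, and with it whether the step from methyl to ethyl stays within the scatter or goes beyond it.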